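The compounds below may be only part of what the source reports. "The series", "measured", "known", "first", "only" and "open" are said of these compounds alone.

In an assay on HEK293 cells for binding affinity to Neuropeptide Y receptor type 5 (Homo sapiens) (a higher number here means a weaker inhibitor, a lower number a stronger inhibitor), compound 2 `COc1ccc2c(c1)CCC(NC[C@H]1CC[C@H](CNS(=O)(=O)c3ccc4ccccc4c3)CC1)C2Cc1ccccc1` gives 443 nM, the higher of the two numbers recorded so far. Within the data shown here, compound 1 `O=C(NC1CCc2cc(F)ccc2C1Cc1cccnc1)[C@H]1CC[C@H](CNS(=O)(=O)c2ccccc2)CC1` gives 40 nM, a gap beyond the scatter, but the two structures differ in more than one place and no single step connects them. Compound 3 `COc1ccc2c(c1)CCC(NC[C@H]1CC[C@H](CNS(=O)(=O)c3ccc4ccccc4c3)CC1)C2Cc1cccnc1` departs from compound 2 by one change: pyridin-3-yl in place of phenyl on a saturated chain carbon bound to a saturated ring carbon. Among the measured compounds shown here, no measured pair isolates this change. The step from compound 2 to compound 3 in this assay is expected to be modest and toward a lower number, a 1.8-fold lower number from compound 2 to compound 3 (0.25 log units; within the scatter). Compound 3 is therefore estimated at 250 nM, within a range from 60 nM to 1000 nM.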

Compound 3, half-maximal inhibitory concentration: 337 nM
The estimate for compound 3 lay 1.3-fold (0.13 log units) below the measured number; the measured number falls inside the stated range.
By their numbers in this assay, from the lowest: compound 1; then compounds 3 and 2 (each within the scatter of the next).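

In this assay, pyridin-3-yl in place of phenyl on a saturated chain carbon bound to a saturated ring carbon gives a 1.3-fold lower number from compound 2 to compound 3 (0.12 log units; within the scatter) as the first single change read at this place. Exchanging one ring carbon for nitrogen, which adds one hydrogen-bond acceptor, therefore produces no shift that can be told from the scatter on this core. No evidence available here bears on this result. From the compounds shown here alone, it remains open whether pyridin-4-yl or a carboxylic acid at this place would shift the number beyond the scatter, and whether phenyl would do so in compound 1, which already carries pyridin-3-yl.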